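Solubility of a pyridinyl-amino series: a carboxylic acid analogue

A few compounds are considered here, and "the series" means these few. Any claim that something is new, unique, unknown or untested is made for them only; others in the source may bear on it.

Compound 1 `COc1cccc(Nc2cc3[nH]c(-c4cccc(C(F)(F)F)c4)nc3cn2)n1`: < 5000 nM
Compound 2 `COc1ccnc(Nc2cc3[nH]c(-c4cccc(C(F)(F)F)c4)nc3cn2)c1`: < 5000 nM
Compound 3 `Fc1ccc(Nc2cc3[nH]c(-c4cccc(C(F)(F)F)c4)nc3cn2)nc1`: < 5000 nM

In a physicochemical assay for solubility, using the shake flask method, in phosphate buffer, measured as kinetic solubility, with a stated time of 20 h, at pH 6.5 (on this read-out higher numbers stand for higher solubility and lower numbers for lower solubility), compound 1 gives only a limit of the assay, < 5000 nM. Compound 2 gives a limit too, and so does compound 3, as the list above shows; the limit of < 5000 nM in this assay, at which 3 of the 3 values shown sit, summarises this. The steps a step that the two limits leave unreadable from compound 1 to compound 2, a step that the two limits leave unreadable from compound 1 to compound 3 and a step that the two limits leave unreadable from compound 2 to compound 3 are therefore all unreadable. Compound 4 `O=C(O)c1ccnc(Nc2cc3[nH]c(-c4cccc(C(F)(F)F)c4)nc3cn2)c1` differs from compound 1 as follows: 4-carboxypyridin-2-yl in place of 6-methoxypyridin-2-yl on a nitrogen on an aromatic ring. For the measured compounds named here, no measured step reads on this change, so the expectation rests on the structural change alone. Compound 4 is expected to give 20000 nM in this assay, between 3000 nM and 150000 nM, a step of an at least 4.0-fold higher number from compound 1 to compound 4 (0.60 log units; beyond the scatter) that is itself uncertain since compound 1 is known only as a limit.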

Compound 4, solubility: < 5000 nM
Compound 4 gave a limit, no number; the forecaster's own chance of this, stated with the estimate: 35%; at least 4.0-fold (0.60 log units) between middle value and limit.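

Compound 4 also gives only a limit, so its steps from compound 1, compound 2 and compound 3 cannot be read: the limit of < 5000 nM in this assay, at which 4 of the 4 values shown sit.

The compounds shown leave open how the true solubilities of these four compounds compare, including whether 4-carboxypyridin-2-yl makes any difference.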